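Working notes: from compound 3 to compound 4

The compounds below may be only part of what the source reports. "The series", "measured", "known", "first", "only" and "open" are said of these compounds alone.

- compound 1 `CC(C)(C)OC(=O)N1CCN(c2c(C(=O)NCc3ccc(F)cc3)nc(Br)c3cccnc23)CC1` gives 10000 nM
- compound 2 `CN(C)CCCNc1c(C(=O)NCc2ccc(F)cc2)nc(Br)c2cccnc12` gives 7000 nM
- compound 3 `COc1cccc(CNC(=O)c2nc(Br)c3cccnc3c2N[C@H]2CC[C@H](N)CC2)c1` gives 7000 nM

In a functional assay on MDA-MB-435 cells (Homo sapiens) for cytotoxicity, read by MTT assay, with a stated time of 72 h (a lower number here means a stronger inhibitor, a higher number a weaker inhibitor), compound 3 gives 7000 nM, level with compound 2 at 7000 nM. Compound 1 at 10000 nM lies within the scatter of both, so the three measured values cannot be ranked.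

Compound 4 `CN(C)c1ccc(CNC(=O)c2nc(Br)c3cccnc3c2N[C@H]2CC[C@H](N)CC2)cc1` differs from compound 3 in one place: 4-(dimethylamino)phenyl in place of 3-methoxyphenyl on a saturated chain carbon bound to an amide-type nitrogen. It carries 4-(dimethylamino)phenyl in place of 3-methoxyphenyl on a saturated chain carbon bound to an amide-type nitrogen.

Going by the values given here, no measured pair isolates a single change, so the data give no direct size for this one. In this assay no step beyond the scatter is expected, and no direction is favoured. This expectation rests on compound 3 at 7000 nM and on the close agreement of the other two values. The expected change is a 1.2-fold lower number from compound 3 to compound 4 (0.07 log units; within the scatter). For compound 4 the estimated value is 6000 nM, with an expected range from 2000 nM to 15000 nM.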

Compound 4, half-maximal inhibitory concentration: 4000 nM
Estimate against measurement, compound 4: 1.5-fold (0.18 log units) above; the measured number falls inside the stated range.
By their numbers in this assay, from the lowest: compounds 4, 2, 3 and 1 (each within the scatter of the next, the first and the last beyond it).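

In this assay, going by these compounds alone, the only single-place step, 4-(dimethylamino)phenyl in place of 3-methoxyphenyl on a saturated chain carbon bound to an amide-type nitrogen, reads as a 1.8-fold lower number from compound 3 to compound 4 (0.24 log units; within the scatter) and so stays inside the usual scatter. This position therefore accepts a change of both the substituent and its place on the aromatic ring without a step that can be told from repeat variation. Within the data shown here, with one step, this describes only this pair and gives no trend for the position. No measurement at hand bears on why the step has this size.

The exchange alters the substituent and its ring place together, so 4-methoxyphenyl or 3-(dimethylamino)phenyl would be needed to separate the two. From the compounds shown here alone, whether an unsubstituted phenyl, a carboxylic acid or a longer chain at this place would shift the number beyond the scatter remains open.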